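This account rests on a few compounds, and the source may have more. Where it says the series, first, only, none or still open, it means among the compounds named here.

Compound 1 `COc1cccc(Oc2ccc3c(NCCCNCc4cc(F)ccc4OC)ccnc3c2)c1`: 14500 nM
Compound 2 `COc1ccc(F)cc1CNCCCNc1ccnc2cc(CC3CCCCC3)ccc12`: 4200 nM

In a physicochemical assay for solubility, with a stated time of 18 h, at pH 7.4 (a higher number here means a more soluble compound, a lower number a less soluble compound), compound 2 gives 4200 nM, the lower of the two numbers, while compound 1 gives 14500 nM. Compound 3 `COc1ccc(F)cc1CNCCCNc1ccnc2cc(Oc3ccccc3OC)ccc12` differs from compound 2 by 2-methoxyphenoxy in place of cyclohexylmethyl on an aromatic carbon. Going by the values given here, the one measured step that bears on this is a 3.5-fold lower number from compound 1 to compound 2 (0.54 log units; beyond the scatter), which is close to the reverse of the present change, the entering group being 2-methoxyphenoxy rather than 3-methoxyphenoxy. Compound 3 is therefore expected to show a rise of similar size, a 2.9-fold higher number from compound 2 to compound 3 (0.46 log units; beyond the scatter). Compound 3 is estimated at 12000 nM, with a range from 5000 nM to 30000 nM.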

Compound 3, solubility: 14500 nM
The estimate for compound 3 lay 1.2-fold (0.08 log units) below the measured number, and the stated range covers the measured number.
By their numbers in this assay, from the lowest: compound 2; then compounds 1 and 3 (each within the scatter of the next).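

In this assay, 2-methoxyphenoxy in place of cyclohexylmethyl on this aromatic carbon gives a 3.5-fold higher number from compound 2 to compound 3 (0.54 log units; beyond the scatter), so the step seen earlier with 3-methoxyphenoxy now appears with a second phenoxy group. Moving the methoxy around that outer ring gives no change at the digits printed from compound 1 to compound 3 (within the scatter), so in this pair its place on the ring makes no difference to the reading. Nothing shown gives a reason for these numbers. Going by these compounds, this change alters the ring and the linking atom together, so it remains open which of them carries the step. A cyclohexyloxy or benzyl group would separate the two.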